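A few compounds are considered here, and "the series" means these few. Any claim that something is new, unique, unknown or untested is made for them only; others in the source may bear on it.

Working notes on the series in a functional assay on HepG2 cells (Homo sapiens) for cytotoxicity, read by MTT assay, with a stated time of 48 h; on this read-out lower numbers stand for stronger inhibition and higher numbers for weaker inhibition. Compound 1 (`O=C1/C(=C\c2ccc([N+](=O)[O-])cc2)S/C(=N/c2ccccc2)N1Cc1ccncc1`) gives 18900 nM, compound 2 (`CC(C)c1ccc(/C=C2/S/C(=N/c3ccccc3)N(Cc3ccncc3)C2=O)cc1`) gives 32300 nM and compound 3 (`COc1ccc(/C=C2/S/C(=N/c3ccccc3)N(Cc3ccncc3)C2=O)cc1OC`) gives 28900 nM. Compound 3 has no separate place among these three numbers: a 1.1-fold lower number from compound 2 to compound 3 (0.05 log units; within the scatter), and a 1.5-fold higher number from compound 1 to compound 3 (0.18 log units; within the scatter).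

Compound 4 (`COc1ccc(OC)c(/C=C2/S/C(=N/c3ccccc3)N(Cc3ccncc3)C2=O)c1`) has the same atoms as compound 3, joined differently: 2,5-dimethoxyphenyl in place of 3,4-dimethoxyphenyl on a double-bonded chain carbon bound to a double-bonded ring carbon, (2,5-dimethoxyphenyl in place of 3,4-dimethoxyphenyl on a double-bonded chain carbon bound to a double-bonded ring carbon).

The two steps above bear most directly on this change, since both exchange the group at that same place, and neither leaves the scatter. The remaining step, a 1.7-fold higher number from compound 1 to compound 2 (0.23 log units; within the scatter), also stays within it. Across these three compounds, then, exchanging this group has not yet produced a step beyond the scatter. Within the data shown here, no measured compound carries 2,5-dimethoxyphenyl, so the data hold no direct test of this change. On that basis, no step beyond the scatter is expected in this assay, and no direction is favoured. The estimated step is a 1.0-fold lower number from compound 3 to compound 4 (0.01 log units; within the scatter). For compound 4 the estimate is 28000 nM, with an expected range from 15000 nM to 52000 nM.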

Compound 4, half-maximal inhibitory concentration: 35800 nM
Compound 4: middle estimate off by 1.3-fold (0.11 log units), on the low side; measured number inside the range.
By their numbers in this assay, from the lowest: compounds 1, 3, 2 and 4 (each within the scatter of the next).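

In this assay, among these compounds, the result gives the first reading of how the two methoxy groups are arranged at this place, on a double-bonded chain carbon bound to a double-bonded ring carbon. Replacing 3,4-dimethoxyphenyl with 2,5-dimethoxyphenyl, with the atoms unaltered, gives (a 1.2-fold higher number from compound 3 to compound 4 (0.09 log units; within the scatter)), so this rearrangement does not separate the two isomers. The new group also stays within the scatter of 4-isopropylphenyl (a 1.1-fold higher number from compound 2 to compound 4 (0.04 log units; within the scatter)) and 4-nitrophenyl (a 1.9-fold higher number from compound 1 to compound 4 (0.28 log units; within the scatter)), so all four groups at this place remain unseparated, and no information is available to explain this result.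

The compounds shown leave open whether a carboxylic acid, an amine or a hydroxyl on the aromatic ring at this place would give a step beyond the scatter, since every group so far is a substituted phenyl of the kinds above. They also leave open whether a longer chain between that ring and the shared core, or any exchange elsewhere on the core, would move the number in this assay beyond the scatter.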